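The source may report more compounds than this note shows. Statements on the series, on what has been measured and on what is new or still open speak of the compounds shown alone.

Going by the values given here, in a functional assay on IGROV-1 cells (Homo sapiens) for inhibition (on this read-out higher numbers stand for weaker inhibition of growth and lower numbers for stronger inhibition of growth), only two compounds have numbers so far. Compound 1 `COc1cc(-c2nncn2-c2ccc(N(C)C)cc2)cc(OC)c1OC` gives 95.5 nM, while compound 2 `COc1ccc(-n2cnnc2-c2cc(OC)c(OC)c(OC)c2)cc1O` gives 447 nM. Compound 2 therefore holds the higher of the two numbers, which means the weaker inhibition of growth, and its gap to compound 1 lies beyond the usual scatter of repeated measurements.

Compound 3 `COc1ccc(-n2cnnc2-c2cc(OC)c(OC)c(OC)c2)cc1F` departs from compound 2 at a single place: fluoro in place of hydroxy on an aromatic carbon. Among the compounds with values here, no pair of measured compounds shows this swap, so the expectation has no direct precedent and must stay cautious. A single small substituent is changing, so a modest shift in this assay seems most likely, probably no larger than the scatter, with a slight lean toward a lower number. The expected size of the change is a 1.5-fold lower number from compound 2 to compound 3 (0.17 log units; within the scatter). The estimated value for compound 3 is 300 nM, with an expected range from 80 nM to 1100 nM.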

Compound 3, concentration for 50% growth inhibition: 4900 nM
Compound 3: middle estimate off by 16-fold (1.21 log units), on the low side, and the stated range ends below it.
By their numbers in this assay, from the lowest: compound 1; then compound 2; then compound 3.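

In this assay, putting fluoro in place of hydroxy on this aromatic carbon gives an 11-fold higher number from compound 2 to compound 3 (1.04 log units; beyond the scatter) and so a much weaker inhibition of growth. Going by these compounds alone, this is the first step at this place, ortho to a methoxy group and meta to a large group, and it shows that exchanging one heavy atom here can shift the number well beyond the scatter. Hydroxy counts one hydrogen-bond donor and one acceptor while fluoro counts neither, but this difference is only an observation, and nothing measured here explains the rise in the number.

From the compounds shown here alone, it remains open whether the weaker inhibition reflects the loss of hydroxy or the arrival of fluoro, and how a plain hydrogen, an amino group or a carboxylic acid at this place would compare with either. Compound 1 differs from compound 2 in more than one place, so it cannot settle what this position prefers.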